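This account rests on a few compounds, and the source may have more. Where it says the series, first, only, none or still open, it means among the compounds named here.

Three compounds share one core and differ only in the group fixed to one carbon of the aromatic ring that carries the trifluoromethyl group. Compound 1 `CC(C(=O)NCc1ccc(C(F)(F)F)cc1N1CCCC1)c1ccc(NS(C)(=O)=O)c(F)c1` gives 2.3 nM in an assay on CHO cells for antagonist activity at transient receptor potential cation channel subfamily V member 1 (Homo sapiens), read by FLIPR; on this read-out lower numbers stand for stronger inhibition and higher numbers for weaker inhibition. Compound 2 `CCCOc1cc(C(F)(F)F)ccc1CNC(=O)C(C)c1ccc(NS(C)(=O)=O)c(F)c1` gives 2 nM, a change of a 1.2-fold lower number from compound 1 to compound 2 (0.06 log units; within the scatter). Compound 3 `CC(C)CCOc1cc(C(F)(F)F)ccc1CNC(=O)C(C)c1ccc(NS(C)(=O)=O)c(F)c1` gives 0.5 nM, the lowest of the three numbers; the steps from its neighbours are a 4.6-fold lower number from compound 1 to compound 3 (0.66 log units; beyond the scatter) and a 4.0-fold lower number from compound 2 to compound 3 (0.60 log units; beyond the scatter), both beyond the scatter, so compound 3 is the strongest inhibitor measured here.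

Compound 4 `CC(C(=O)NCc1ccc(C(F)(F)F)cc1SC1CCCC1)c1ccc(NS(C)(=O)=O)c(F)c1` has not yet been measured. Relative to compound 3 the change is cyclopentylsulfanyl in place of isopentyloxy on an aromatic carbon of a six-membered aromatic ring of carbon only. Two of the measured steps bear on this. Compound 1 carried a ring at the same place and gave a higher number than compound 3 by a 4.6-fold lower number from compound 1 to compound 3 (0.66 log units; beyond the scatter); the chain lengthening by a 4.0-fold lower number from compound 2 to compound 3 (0.60 log units; beyond the scatter) shows that the size of the group at this position matters. Compound 4 brings back a ring, though with sulfur rather than nitrogen or oxygen as its link, so a modest rise toward compound 1 is expected, with a 3.0-fold higher number from compound 3 to compound 4 (0.48 log units; beyond the scatter). Compound 4 is therefore estimated at 1.5 nM, within 0.4 nM to 6 nM.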

Compound 4, inhibition constant: 0.3 nM
The estimate for compound 4 lay 5.0-fold (0.70 log units) above the measured number, outside the stated range (below it).
By their numbers in this assay, from the lowest: compounds 4 and 3 (each within the scatter of the next); then compounds 2 and 1 (each within the scatter of the next).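

In this assay, cyclopentylsulfanyl in place of isopentyloxy leaves the number within the scatter (a 1.7-fold lower number from compound 3 to compound 4 (0.22 log units; within the scatter)), so on this aromatic carbon an open chain linked through oxygen and a five-membered ring linked through sulfur, each with 6 heavy atoms, cannot be told apart. A ring at this position therefore does not by itself go with a higher number, as compound 1 alone might have suggested: cyclopentylsulfanyl stands beyond the scatter from propoxy (a 6.7-fold lower number from compound 2 to compound 4 (0.82 log units; beyond the scatter)) and from pyrrolidin-1-yl (a 7.7-fold lower number from compound 1 to compound 4 (0.88 log units; beyond the scatter)). Nothing measured here explains why these groups give the numbers they do.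

This change swaps the linking atom and the shape of the group together, so the compounds shown cannot separate the two; cyclopentyloxy and isopentylsulfanyl would each alter only one of them. As far as these compounds go, how far the position accepts other groups also stays open, for example a larger ring such as cyclohexylsulfanyl, a longer chain such as hexyloxy, or a chain ending in an amine or a carboxylic acid.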